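The source may report more compounds than this note shows. Statements on the series, on what has been measured and on what is new or still open speak of the compounds shown alone.

Measured so far in a functional assay on KB cells (Homo sapiens) for antiproliferative activity, read by sulforhodamine B assay, with a stated time of 3 days; on this read-out higher numbers stand for an effect only at larger amounts of compound and lower numbers for an effect already at smaller amounts:
compound 1 `CCC1=C(O)c2c(oc(-c3cccc(C)c3)cc2=O)C(CC)(CC)C1=O` gives 49.7 uM;
compound 2 `CCC1=C(O)c2c(oc(-c3cc(OC)c(OC)c(OC)c3)cc2=O)C(CC)(CC)C1=O` gives 46.7 uM;
compound 3 `CCC1=C(O)c2c(oc(-c3cc(Cl)c(OC)c(OC)c3)cc2=O)C(CC)(CC)C1=O` gives 21.8 uM.

Compound 1 holds the highest of the three numbers in this assay. Compound 2 sits within the scatter of compound 1, so the two cannot be ordered; compound 3 lies beyond the scatter from compound 1. Among the compounds with values here, the one step between measured neighbours is a 2.1-fold lower number from compound 2 to compound 3 (0.33 log units; beyond the scatter), chloro in place of methoxy on an aromatic carbon, a modest change.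

Compound 4 `CCC1=C(O)c2c(oc(-c3ccc(O)c(C)c3C)cc2=O)C(CC)(CC)C1=O` is compound 1 with 4-hydroxy-2,3-dimethylphenyl in place of 3-methylphenyl on an aromatic carbon. Within the data shown here, no measured step covers this change: the set contains no exchange of a hydroxy and no added methyl groups on the aryl group, and the single step between compound 2 and compound 3 concerns a different exchange. Among the measured compounds shown here, it shows only that a single substituent exchange on that aryl group moved this assay by a modest amount, so a step of comparable or smaller size, in either direction, is expected here, and no direction can be taken from the data with confidence. The estimate therefore stays close to compound 1, leaning slightly toward a lower number, as a 1.4-fold lower number from compound 1 to compound 4 (0.15 log units; within the scatter).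

For compound 4 in this assay the expected value is 35 uM, with a range from 12 uM to 100 uM.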

Compound 4, concentration for half-maximal effect: 6.5 uM
Compound 4: middle estimate off by 5.4-fold (0.73 log units), on the high side, and the stated range ends above it.
By their numbers in this assay, from the lowest: compound 4; then compound 3; then compounds 2 and 1 (each within the scatter of the next).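

Working notes on the aryl group on the aromatic carbon next to the ring oxygen: in this assay this position responds to a change in the aryl group by more than the earlier compounds showed, with a 7.6-fold lower number from compound 1 to compound 4 (0.88 log units; beyond the scatter) for 4-hydroxy-2,3-dimethylphenyl in place of 3-methylphenyl, against a 2.1-fold lower number from compound 2 to compound 3 (0.33 log units; beyond the scatter) for chloro in place of methoxy. The entering group adds a hydrogen-bond donor and a hydrogen-bond acceptor to the aryl group, which the aryl groups of compound 1, compound 2 and compound 3 lack, and with it compound 4 holds the lowest number of the four, so lower numbers on this core are not limited to the range those three span. No measurement available here explains the step.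

The single exchange in compound 4 brings in the hydroxy and the additional methyl group together, so the compounds shown do not divide the step between them, and a 4-hydroxyphenyl group would be the direct test of the hydroxy alone. Also open, going by these compounds, is whether the step depends on a hydroxy as such, or whether an amine or a carboxylic acid at that place on the aryl group would move this read-out in the same direction.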